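The source may report more compounds than this note shows. Statements on the series, on what has been measured and on what is new or still open speak of the compounds shown alone.

Compounds measured so far:

Compound 1 `CCCCCC(=O)c1ccc(OCCCN2CCN(C(=O)[C@@H](CC(C)C)NC(=O)OC(C)(C)C)CC2)cc1` — 4470 nM
Compound 2 `C[C@@H](NC(=O)OC(C)(C)C)C(=O)N1CCN(CCCOc2ccc(C(=O)C3CC3)cc2)CC1` — 83200 nM
Compound 3 `CNCC(=O)N1CCN(CCCOc2ccc(C(=O)C3CC3)cc2)CC1` — 79400 nM

The read-out throughout is an assay for binding affinity to histamine H2 receptor (Homo sapiens); on this read-out higher numbers stand for weaker inhibition and lower numbers for stronger inhibition. Compound 2 gives the highest of the three numbers. Among the compounds with values here, its nearest neighbour is compound 3, which sits a 1.0-fold lower number from compound 2 to compound 3 (0.02 log units; within the scatter); the furthest is compound 1, whose number lies well beyond the scatter from that of compound 2, though the two differ in more than one place and no single step can be computed between them.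

The unmeasured compound is compound 4 `N[C@H](CC1CCCCC1)C(=O)N1CCN(CCCOc2ccc(C(=O)C3CC3)cc2)CC1`. It differs from compound 2 in one place: 1-amino-2-cyclohexylethyl in place of 1-((tert-butoxycarbonyl)amino)ethyl on a carbonyl carbon. Within the data shown here, the change thus both removes the tert-butoxycarbonyl protection from the nitrogen and exchanges the methyl side chain for a cyclohexylmethyl one, the carbonyl carbon carrying the group being the one whose other neighbour is the amide-type nitrogen in a ring.

Among the measured compounds shown here, only one measured step bears on this. From compound 2 to compound 3, removing the tert-butoxycarbonyl group and shrinking the side chain left the number where it was, within the scatter. For the measured compounds named here, the data hold no step that isolates the effect of a larger side chain on this read-out, so the direction for compound 4 rests on expectation rather than on a measured precedent. On that basis compound 4 is expected to show a modest move toward a lower number, a 2.8-fold lower number from compound 2 to compound 4 (0.44 log units; beyond the scatter). The estimate for compound 4 in this assay is 30000 nM, with a range from 8000 nM to 100000 nM.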

Compound 4, inhibition constant: 20400 nM
The estimate for compound 4 lay 1.5-fold (0.17 log units) above the measured number, and the stated range covers the measured number.
By their numbers in this assay, from the lowest: compound 1; then compound 4; then compounds 3 and 2 (each within the scatter of the next).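

In this assay, the group on a carbonyl carbon whose other neighbour is the amide-type nitrogen in a ring now proves able to shift the number beyond the scatter: 1-amino-2-cyclohexylethyl in place of 1-((tert-butoxycarbonyl)amino)ethyl gives a 4.1-fold lower number from compound 2 to compound 4 (0.61 log units; beyond the scatter), whereas the earlier change at this place gave only a 1.0-fold lower number from compound 2 to compound 3 (0.02 log units; within the scatter). The same group in place of (methylamino)methyl gives a 3.9-fold lower number from compound 3 to compound 4 (0.59 log units; beyond the scatter), so the two comparisons agree in direction and both steps are modest. No measurement shown here accounts for these shifts.

The step from compound 2 to compound 4 changes the tert-butoxycarbonyl protection and the side chain together, so the compounds shown do not separate the two; a free amine carrying the methyl side chain, or a tert-butoxycarbonyl-protected amine carrying the cyclohexylmethyl side chain, would be needed to do so. On these data alone, it also remains open whether the six-membered ring of carbon only matters as such, which a phenyl ring or a plain isobutyl side chain at this place, on the core of compound 4, could test.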